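A cyclopropyl group in place of an ester chain

This account rests on a few compounds, and the source may have more. Where it says the series, first, only, none or still open, it means among the compounds named here.

In a functional assay (strain AB) with Danio rerio as the target, read by microscopy, with a stated time of 1 h (on this read-out higher numbers stand for an effect only at larger amounts of compound and lower numbers for an effect already at smaller amounts), three compounds sharing one core have been measured. Compound 1 `COCCCN1CCc2c(sc(NC(=O)Nc3ccc(Cl)cc3)c2C(N)=O)C1` gives 2400 nM. Compound 2 `CC(C)(C)OC(=O)CCC[N+]1(C)CCc2c(sc(NC(=O)Nc3ccc(Cl)cc3)c2C(N)=O)C1` gives 250 nM, and compound 3 `CC[N+]1(CC)CCc2c(sc(NC(=O)Nc3ccc(Cl)cc3)c2C(N)=O)C1` gives 450 nM. Compound 2 thus holds the lowest number of the three, yet compound 3 stands within the scatter of it, while compound 1 stands beyond it. Compound 4 `C[N+]1(CC2CC2)CCc2c(sc(NC(=O)Nc3ccc(Cl)cc3)c2C(N)=O)C1` has not yet been measured in this assay. It differs from compound 2 in one place: cyclopropyl in place of 2-(tert-butoxycarbonyl)ethyl on a saturated chain carbon bound to an amine nitrogen in a ring. Among the compounds with values here, no measured pair shows this change. Compound 2 and compound 3 each carry a charged ring nitrogen with different groups on it, and their numbers lie within the scatter of each other; compound 4 keeps that charged nitrogen. A step from compound 2 to compound 4 of a 1.4-fold higher number from compound 2 to compound 4 (0.15 log units; within the scatter) is therefore expected, none beyond the scatter. For compound 4 an estimate of 350 nM is given, with a range from 120 nM to 1000 nM.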

Compound 4, half-maximal effective concentration: 360 nM
For compound 4 the middle estimate is 1.0-fold (0.01 log units) below the measured one; the range from low to high includes it.
By their numbers in this assay, from the lowest: compounds 2, 4 and 3 (each within the scatter of the next); then compound 1.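

Within the data shown here, compound 4 gives the first measured pair at this position: in this assay, cyclopropyl in place of 2-(tert-butoxycarbonyl)ethyl on a saturated chain carbon bound to an amine nitrogen in a ring gives a 1.4-fold higher number from compound 2 to compound 4 (0.16 log units; within the scatter). The ester chain, with its double bond and two hydrogen-bond acceptors, can therefore leave and a three-membered carbon ring with no acceptors can enter without a step beyond the scatter, so neither the acceptors nor the larger group is needed to keep the number at this place. Nothing measured here explains why the two groups read alike.

On these data alone, it remains open how a carboxylic acid in place of the tert-butyl ester, or an amine at the end of the chain, reads at this position. Also open, as far as these compounds go, is how cyclopropylmethyl reads on a ring nitrogen without the added methyl.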